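Nitro in place of isopropyl on the aromatic ring

The compounds below may be only part of what the source reports. "The series", "measured", "known", "first", "only" and "open" are said of these compounds alone.

Compound 3 `CC(C)c1ccc(N2C(=O)C=CC2OCC(F)(F)F)cc1` gives 6620 nM in a functional assay on K562 cells (Homo sapiens) for inhibition (on this read-out lower numbers stand for stronger inhibition and higher numbers for weaker inhibition), the highest of the three numbers shown, though its gaps to compound 1 `CCc1ccc(N2C(=O)C=CC2OCC(F)(F)F)cc1` at 4470 nM and to compound 2 `O=C1C=CC(OC(C(F)(F)F)C(F)(F)F)N1c1ccc(Cl)cc1` at 4480 nM both lie within the scatter. Compound 4 `O=C1C=CC(OCC(F)(F)F)N1c1ccc([N+](=O)[O-])cc1` differs from compound 3 by nitro in place of isopropyl on an aromatic carbon. Going by the values given here, the only single-place step measured, a 1.5-fold higher number from compound 1 to compound 3 (0.17 log units; within the scatter), exchanges hydrogen and methyl on a chain carbon and says nothing about a nitro group. Compound 2 carries a chlorine substituent and a different ether, differing in two places, yet sits in the same range. Among the compounds with values here, no step in this set exceeds the scatter. Compound 4 is therefore expected to show a 1.1-fold lower number from compound 3 to compound 4 (0.04 log units; within the scatter), nothing beyond the scatter. The estimate for compound 4 is 6000 nM, with a range from 2000 nM to 18000 nM.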

Compound 4, half-maximal inhibitory concentration: 1530 nM
Beside the measured number, compound 4's estimate is 3.9-fold (0.59 log units) above it, outside the stated range (below it).
By their numbers in this assay, from the lowest: compound 4; then compounds 1, 2 and 3 (each within the scatter of the next).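

At the aromatic carbon para to a large group, nitro separates from the alkyl groups in this assay: nitro in place of isopropyl gives a 4.3-fold lower number from compound 3 to compound 4 (0.64 log units; beyond the scatter), and nitro in place of ethyl gives a 2.9-fold lower number from compound 1 to compound 4 (0.47 log units; beyond the scatter). Ethyl and isopropyl had stayed within the scatter of each other, so this is the first change at this position that the read-out resolves. No measured property bears on these steps. Open, going by these compounds, is how an amine, a nitrile or a carboxylic acid on the same carbon would read. Also open, on these data alone, is whether the nitro step holds with the ether of compound 2.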